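The compounds below may be only part of what the source reports. "The series", "measured", "known", "first", "only" and "open" are said of these compounds alone.

Measured so far in a physicochemical assay for lipophilicity, read by spectrophotometry, measured as octanol-water partition, at pH 7.4; on this read-out higher numbers stand for higher lipophilicity and lower numbers for lower lipophilicity:
compound 1 (`CCOc1cc(CN2CCC(NC(=O)c3ccc(N)nc3)CC2)cc(OCc2ccccc2)c1-c1ccc(F)cc1`) gives 3.94
compound 2 (`CCOc1cc(CN2CCC[C@@H](NC(=O)c3cncc(C)c3)CC2)cc(OCC)c1F`) gives "not determined" (no result reported)
compound 3 (`CCOc1cc(CN2CCC(NC(=O)c3cncc(C)c3)CC2)ccc1C`) gives 3.03

Among the compounds with values here, only two of these three compounds carry a number. Compound 1 holds the higher one, and compound 3 sits beyond the usual scatter below it. Compound 2 has no number to place beside them.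

The account now turns to compound 4 (`CCOc1cc(CN2CCC(NC(=O)c3ccc(N)nc3)CC2)cc(OCC)c1-c1ccc(F)cc1`), which has not yet been measured in this assay. It keeps the core of compound 1 and changes in one place (methyl in place of phenyl on a saturated chain carbon bound to an oxygen on an aromatic ring), so that benzyloxy becomes ethoxy. Within the data shown here, no measured pair in this small set shows this change alone. Compound 1 and compound 3 differ in more than one place, so the value of compound 3, 3.03, sets no size for it. The expectation therefore rests on the structural change itself, the loss of a six-membered aromatic ring of carbon only, and it points to a lower number, beyond the scatter. The expected change is a number 0.74 log units lower from compound 1 to compound 4 (beyond the scatter). Compound 4 is estimated at 3.2, with an expected range from 2.8 to 3.6.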

Compound 4, distribution coefficient: 3.15
For compound 4 the middle estimate is 0.05 log units above the measured one; low and high end bracket the measured number.
By their numbers in this assay, from the lowest: compounds 3 and 4 (each within the scatter of the next); then compound 1.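

In this assay, within the data shown here, the replacement of phenyl by methyl on a saturated chain carbon bound to an oxygen on an aromatic ring, which turns benzyloxy into ethoxy, gives a number 0.79 log units lower from compound 1 to compound 4 (beyond the scatter) and supplies the first step in this set that can be read at a single place. Among these compounds, until now the set held no pair differing in one place only, so this change had no measured size. The step now ties a size to the loss of one six-membered aromatic ring of carbon only, a change in which no hydrogen-bond donors or acceptors leave or enter. Nothing at hand accounts for the size of this step.

On these data alone, this size rests on a single pair, so whether it would hold on a core other than that of compound 1 remains open. Also open, as far as these compounds go, is where a group between the two at this place would fall, such as propoxy, and what a chain ending in an amine or a carboxylic acid would read there in this assay.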